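The compounds below may be only part of what the source reports. "The series", "measured", "known", "first", "only" and "open" are said of these compounds alone.

Measured in an ADME assay on HeLa cells (Homo sapiens) for inhibition, read by MTT assay, with a stated time of 48 h; on this read-out lower numbers stand for stronger inhibition and higher numbers for weaker inhibition:
- Compound 1 `CCOC(=O)C(=O)CC(=O)/C=C/c1cn(Cc2ccc(Cl)cc2)c2ccccc12`: "not determined" (no result reported)
- Compound 2 `CC(C)CCn1cc(/C=C/C(=O)CC(=O)C(=O)O)c2ccccc21`: > 80000 nM, a limit
- Compound 3 `O=C(/C=C/c1cn(Cc2ccccc2)c2ccccc12)CC(=O)C(=O)O`: > 40000 nM, a limit

Compound 3 gives > 40000 nM, which is a limit of the assay and not a number. Compound 4 `O=C(/C=C/c1cn(Cc2ccc(Cl)cc2)c2ccccc12)CC(=O)C(=O)O` is still to be measured. It has chloro in place of hydrogen on an aromatic carbon, para to a large group, so benzyl becomes 4-chlorobenzyl: chloro in place of hydrogen on an aromatic carbon.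

Within the data shown here, only one measured step bears on this change, a step that the two limits leave unreadable from compound 2 to compound 3, and it gives no size to work from. It also concerns a different part of the molecule. Compound 1 carries the same 4-chlorobenzyl group but has no result, so it offers no guide.

With no readable step to build on, the expectation rests on compound 3 and its limit of > 40000 nM. The expected change is a step that the limit leaves unreadable from compound 3 to compound 4, with no shift in either direction beyond the usual scatter. In this assay, the estimate for compound 4 is 50000 nM, with an expected range from 20000 nM to 100000 nM, and the result may well be reported only as a limit.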

Compound 4, half-maximal inhibitory concentration: > 40000 nM
Compound 4 was reported as a limit (the forecaster's own chance of this, stated with the estimate: 70%); the middle value is on the limit's open side.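

The steps among compound 2, compound 3 and compound 4 cannot be read, as all three values are limits of the assay and not numbers. Going by these compounds, whether 4-chlorobenzyl in place of benzyl changes inhibition at all in this assay, and in which direction, remains open.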